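The source may report more compounds than this note shows. Statements on the series, on what has been measured and on what is new or still open speak of the compounds shown alone.

For the measured compounds named here, compound 2 `C/C=C1/[C@H](O[C@@H]2O[C@H](CO)[C@@H](O)[C@H](O)[C@H]2O)OC=C(C(=O)OC)[C@H]1CC(=O)OCCC(C)C` is, in a functional assay on SK-BR-3 cells (Homo sapiens) for antiproliferative activity, read by MTT assay, with a stated time of 72 h (on this read-out lower numbers stand for stronger inhibition and higher numbers for weaker inhibition), the only compound with a number: compound 2 gives 9020 nM. Compound 1 `C/C=C1/[C@H](O[C@@H]2O[C@H](CO)[C@@H](O)[C@H](O)[C@H]2O)OC=C(C(=O)OC)[C@H]1CC(=O)O` gives > 15000 nM in this assay, and that is a limit of the assay rather than a number (the limit of > 15000 nM in this assay, at which 1 of the 2 values shown sits). Going by the values given here, the one measured step is an at least 1.6-fold lower number from compound 1 to compound 2 (0.22 log units; that floor lies within the scatter). Compound 3 `C/C=C1/[C@H](O[C@@H]2O[C@H](CO)[C@@H](O)[C@H](O)[C@H]2O)OC=C(C(=O)OC)[C@H]1CC(=O)OCCc1ccc(O)cc1` differs from compound 2 by 4-hydroxyphenyl in place of isopropyl on a saturated chain carbon, two bonds along the chain from an oxygen next to a carbonyl group. That step touched the same oxygen but only by adding the chain, so it offers little guidance here. For compound 3 the expected step is a 1.1-fold lower number from compound 2 to compound 3 (0.05 log units; within the scatter), not beyond the scatter. Compound 3 is therefore estimated at 8000 nM, between 3000 nM and 20000 nM.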

Compound 3, half-maximal inhibitory concentration: > 20000 nM
Compound 3 gave a limit, no number; the forecaster's own chance of this, stated with the estimate: 25%; middle value at least 2.5-fold (0.39 log units) from the limit.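

In this assay, putting 4-hydroxyphenyl in place of isopropyl on the chain gives an at least 2.2-fold higher number from compound 2 to compound 3 (0.34 log units; beyond the scatter). The earlier pair only showed that adding the isopentyl chain left no step beyond the scatter, whereas this pair shows that what sits at the end of the chain can matter, and that this ring does not improve on isopropyl. Compound 3 gives a limit and not a number: the limit of > 20000 nM in this assay, at which 1 of the 3 values shown sits.

Compound 1 and compound 3 both stand at limits, so the step between them cannot be read. On these data alone, how much of the loss belongs to the ring and how much to its hydroxyl stays open, and a plain phenyl on the same chain would separate the two.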